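Dimethylamino in place of phenoxy on the pyrazole series

The source may report more compounds than this note shows. Statements on the series, on what has been measured and on what is new or still open speak of the compounds shown alone.

Measured compounds:
compound 1, `COc1cc(C)cc(-c2c(-c3ccnc(-c4ccc(C(C)=O)cc4)c3)cnn2CC#N)c1`: > 100000 nM
compound 2, `Cc1cc(O)cc(-c2nn(CC#N)cc2-c2ccnc(-c3ccc(Oc4ccccc4)cc3)c2)c1`: 15500 nM

In a functional assay on SF-268 cells (Homo sapiens) for inhibition, read by sulforhodamine B assay, with a stated time of 48 h (a higher number here means a weaker inhibitor of growth, a lower number a stronger inhibitor of growth), compound 1 gives > 100000 nM, which is a limit of the assay and not a number (the limit of > 100000 nM in this assay, at which 1 of the 2 values shown sits). Compound 2 gives 15500 nM in this assay, the only number shown in the set. Compound 3, `Cc1cc(O)cc(-c2nn(CC#N)cc2-c2ccnc(-c3ccc(N(C)C)cc3)c2)c1`, is not yet measured; it differs from compound 2 by dimethylamino in place of phenoxy on an aromatic carbon. Going by the values given here, no measured pair shows this change, so the step is expected to be small, in no clear direction, a 1.3-fold higher number from compound 2 to compound 3 (0.11 log units; within the scatter). Compound 3 is estimated at 20000 nM, between 5000 nM and 80000 nM.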

Compound 3, concentration for total growth inhibition: 16900 nM
Compound 3: middle estimate off by 1.2-fold (0.07 log units), on the high side; low and high end bracket the measured number.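

In this assay, the step of a 1.1-fold higher number from compound 2 to compound 3 (0.04 log units; within the scatter) shows that, on this aromatic carbon, dimethylamino can stand in place of phenoxy and the two values stay within the scatter of each other, even though the six-membered aromatic ring of phenoxy leaves with the change. The data shown give no explanation for this result. From the compounds shown here alone, what stays open is whether a primary amine or a carboxylic acid on this carbon would keep the value of compound 3, and whether a longer chain on the nitrogen would do so.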